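Series notes: amine replacement on the cyclohexenyl carbon

This account rests on a few compounds, and the source may have more. Where it says the series, first, only, none or still open, it means among the compounds named here.

In a functional assay on NCI-H929 cells (Homo sapiens) for antiproliferative activity, with a stated time of 24 h (a lower number here means a stronger inhibitor, a higher number a weaker inhibitor), compound 1 `COc1ccc(F)cc1-c1c(F)cnc2[nH]c(C3=CCN([C@H]4CC[C@@H](C(=O)O)CC4)CC3)cc12` gives 35 nM; compound 3 `COc1ccc(F)cc1-c1ccnc2[nH]c(C3=CCN([C@H]4CC[C@@H](C(=O)O)CC4)CC3)cc12` gives 97 nM; compound 2 `COc1ccc(F)cc1-c1ccnc2[nH]c(C3=CCC(N4CCC(C(=O)O)CC4)CC3)cc12` gives 170 nM. Compound 2 is separated beyond the scatter only from compound 1, and sits within the scatter of compound 3. Within the data shown here, the one measured step, a 2.8-fold higher number from compound 1 to compound 3 (0.44 log units; beyond the scatter), concerns an aromatic substituent and not the amine-bearing side. Compound 4 `COc1ccc(F)cc1-c1ccnc2[nH]c(C3=CCC(N[C@@H](C(=O)O)C(C)C)CC3)cc12` differs from compound 2 as follows: (1-carboxy-2-methylpropyl)amino in place of 4-carboxypiperidin-1-yl on a saturated ring carbon. Among the measured compounds shown here, no measured pair in this set shows a change of that kind, so the direction in this assay is open and a step of modest size either way is expected. Compound 4 is estimated at 170 nM (range 50 nM to 600 nM), meaning an expected step of no change at the digits printed from compound 2 to compound 4 (within the scatter).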

Compound 4, half-maximal inhibitory concentration: 76 nM
For compound 4 the middle estimate is 2.2-fold (0.35 log units) above the measured one; measured number inside the range.
By their numbers in this assay, from the lowest: compound 1; then compounds 4, 3 and 2 (each within the scatter of the next, the first and the last beyond it).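

In this assay the saturated ring carbon accepts a group with no ring: (1-carboxy-2-methylpropyl)amino in place of 4-carboxypiperidin-1-yl gives a 2.2-fold lower number from compound 2 to compound 4 (0.35 log units; beyond the scatter). The piperidine ring is therefore not required at this position, and the choice of amine here moves the number beyond the scatter. Nothing available explains this step.

Going by these compounds, whether an ester or an amide in place of the carboxylic acid would hold this gain remains open, as does the effect of the opposite stereocentre. Also open, on these data alone, is whether the aromatic fluoro of compound 1 would add to it.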